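Ester in Place of Hydroxamic Acid on a Quinolinone Sulfonamide

A few compounds are considered here, and "the series" means these few. Any claim that something is new, unique, unknown or untested is made for them only; others in the source may bear on it.

Three compounds on a shared core were tested in a functional assay on HL-60 cells (Homo sapiens) for antiproliferative activity, tested at 20 uM; a lower number here means a weaker effect, a higher number a stronger effect of the compound at the concentration tested. Compound 1 `COC(=O)c1ccc(CS(=O)(=O)Nc2ccc3c(c2)cc(C)c(=O)n3C)cc1` gives 14% in this assay. Compound 2 `Cc1cc2cc(NS(=O)(=O)Cc3ccc(C(=O)NO)cc3)ccc2n(C)c1=O` gives 0% in this assay. Compound 3 `COc1ccc(C(=O)NO)cc1S(=O)(=O)Nc1ccc2c(c1)cc(C)c(=O)n2C` gives 10% in this assay, a number within the scatter of both compound 1 and compound 2.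

Compound 1 arises from compound 2 by one change, (methoxy in place of hydroxyamino on a carbonyl carbon), and that change made a step of a number 14 percentage points higher from compound 2 to compound 1 (beyond the scatter).

Compound 4 `COC(=O)c1ccc(OC)c(S(=O)(=O)Nc2ccc3c(c2)cc(C)c(=O)n3C)c1` has not yet been measured. It arises from compound 3 by methoxy in place of hydroxyamino on a carbonyl carbon, the same change as from compound 2 to compound 1, at a place described in identical terms. The difference between the core of compound 3 and the core of compound 2 is not broken down here.

Compound 4 is therefore expected to give 22% in this assay, with a likely range from 8% to 36%. The expected step of a number 12 percentage points higher from compound 3 to compound 4 (beyond the scatter) rests on a single precedent, because a number 14 percentage points higher from compound 2 to compound 1 (beyond the scatter) was modest, so only a modest rise is anticipated.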

Compound 4, a percentage reported as inhibition, at one concentration (the size of the read-out at that concentration, not a potency): 44%
For compound 4 the middle estimate is 22 percentage points below the measured one, outside the stated range (above it).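

In this assay, methoxy in place of hydroxyamino on a carbonyl carbon gave a number 34 percentage points higher from compound 3 to compound 4 (beyond the scatter), and the same change set beside its earlier counterpart shows a rise on both cores but of unequal size: the same change on two cores in this assay, a number 14 percentage points higher (beyond the scatter) from compound 2 to compound 1 and a number 34 percentage points higher (beyond the scatter) from compound 3 to compound 4, 20 percentage points apart, beyond the scatter of two such steps

In these two pairs, then, the direction of the step carried from one core to the other, while its size did not, so the step measured on one core did not fix its size on the other. The difference between the two cores is not broken down, so the pairs do not show which part of it goes with the larger step, or whether a rise would appear on any further core.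

The compounds shown leave open whether the rise belongs to the methoxycarbonyl group in particular or would also appear with another group on that carbonyl carbon. A carboxylic acid, a simple primary amide or a longer ester such as an ethyl ester, placed on both cores, would bear on that question.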